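The compounds below may be only part of what the source reports. "The series", "measured", "known", "first", "only" and "open" are said of these compounds alone.

Measured in a functional assay on DU-145 cells (Homo sapiens) for cytotoxicity, read by MTT assay; on this read-out higher numbers stand for weaker inhibition and lower numbers for stronger inhibition:
- compound 1 `CC(=O)OCCO[C@H](CC=C(C)C)C1=CC(=O)c2c(O)ccc(O)c2C1=O`: 15500 nM
- compound 2 `CCCC(C)(O)CC(=O)O[C@H](CC=C(C)C)C1=CC(=O)c2c(O)ccc(O)c2C1=O`: 75000 nM

Compound 2 stands highest of the two. Among the compounds with values here, the only measured step, a 4.8-fold higher number from compound 1 to compound 2 (0.68 log units; beyond the scatter), brought in (2-hydroxy-2-methylpentyl)carbonyl in place of 2-acetoxyethyl. Compound 3 `CC(C)=CC[C@@H](OCCO)C1=CC(=O)c2c(O)ccc(O)c2C1=O` differs from compound 2 by 2-hydroxyethyl in place of (2-hydroxy-2-methylpentyl)carbonyl on an oxygen on a saturated carbon. This removes the group that the measured step introduced, so a change of similar size toward a lower number is expected in this assay. The expected step is a 5.0-fold lower number from compound 2 to compound 3 (0.70 log units; beyond the scatter). The estimate for compound 3 is 15000 nM, with an expected range of 6000 nM to 38000 nM.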

Compound 3, half-maximal inhibitory concentration: 9900 nM
Compound 3: the middle estimate sits 1.5-fold (0.18 log units) above what was measured; the measured number falls inside the stated range.
By their numbers in this assay, from the lowest: compounds 3 and 1 (each within the scatter of the next); then compound 2.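

In this assay, 2-hydroxyethyl in place of (2-hydroxy-2-methylpentyl)carbonyl on this oxygen on a saturated carbon gives a step beyond the scatter (a 7.6-fold lower number from compound 2 to compound 3 (0.88 log units; beyond the scatter)). Hydrogen in place of acetyl stays within the scatter (a 1.6-fold lower number from compound 1 to compound 3 (0.19 log units; within the scatter)), so the acetyl makes no readable difference between compound 1 and compound 3. No evidence here accounts for either step.

The larger step changes the size of the group and its carbonyl together, and these cannot be separated. As far as these compounds go, whether an amine, a carboxylic acid or a longer chain at this oxygen would differ from compound 3 remains open.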